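Adding a chloro group to a bromoacrylamide-bearing core

This account rests on a few compounds, and the source may have more. Where it says the series, first, only, none or still open, it means among the compounds named here.

Of the compounds shown here, two have been measured in a functional assay on CCRF-CEM cells (Homo sapiens) for inhibition, read by cell counting, with a stated time of 3 days; on this read-out lower numbers stand for stronger inhibition and higher numbers for weaker inhibition. Compound 1 `Nc1cccc(-c2cn3c(-c4ccc(Cl)cc4)csc3n2)c1` gives 21000 nM in this assay. Compound 2 `C=C(Br)C(=O)Nc1cccc(-c2cn3c(-c4ccccc4)csc3n2)c1` gives 2800 nM in this assay, the lower of the two numbers, so compound 2 currently stands as the stronger inhibitor. Compound 3 `C=C(Br)C(=O)Nc1cccc(-c2cn3c(-c4ccc(Cl)cc4)csc3n2)c1` has not yet been measured; it differs from compound 2 by chloro in place of hydrogen on an aromatic carbon. Among the measured compounds shown here, no measured pair isolates this change, so compound 3 is expected to show a step of a 1.4-fold lower number from compound 2 to compound 3 (0.15 log units; within the scatter) in this assay, toward stronger inhibition but possibly within scatter. The estimate for compound 3 in this assay is 2000 nM, ranging from 700 nM to 6000 nM.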

Compound 3, half-maximal inhibitory concentration: 2200 nM
For compound 3 the middle estimate is 1.1-fold (0.04 log units) below the measured one; low and high end bracket the measured number.
By their numbers in this assay, from the lowest: compounds 3 and 2 (each within the scatter of the next); then compound 1.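

Placing chloro on the aromatic carbon para to a large group gives a 1.3-fold lower number from compound 2 to compound 3 (0.10 log units; within the scatter) in this assay, so phenyl and 4-chlorophenyl cannot be told apart here. With 4-chlorophenyl kept, (1-bromoethenyl)carbonyl in place of hydrogen on the nitrogen gives a 9.5-fold lower number from compound 1 to compound 3 (0.98 log units; beyond the scatter), the first single change shown to reach beyond the scatter. No measurement available here explains either step.

Still open, as far as these compounds go, is whether a methoxy group or an amine on that same ring carbon would differ more from hydrogen. Also open, from the compounds shown here alone, is whether a plain acrylamide, without the bromine, would keep the step seen for the nitrogen.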